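The source may hold more compounds than are shown below. What is called first, only, known or untested is meant among the compounds shown, and "the series" means these compounds.

In a functional assay on MCF7 cells (Homo sapiens) for cytotoxicity, read by MTT assay, with a stated time of 72 h (a higher number here means a weaker inhibitor, a lower number a stronger inhibitor), compound 3 `COc1ccc(C=C2C(=O)N(c3ccc(Cl)cc3)N(c3ccc(Cl)cc3)C2=O)cc1OC` gives > 128000 nM, which is a limit of the assay and not a number. Compound 1 `CN(C)c1ccc(C=C2C(=O)N(c3ccc(Cl)cc3)N(c3ccc(Cl)cc3)C2=O)cc1` gives > 128000 nM, which is also a limit. Within the data shown here, compound 2 `COc1cccc(C=C2C(=O)N(c3ccc(Cl)cc3)N(c3ccc(Cl)cc3)C2=O)c1O` gives 26700 nM, the only true number so far.

Compound 4 `O=C1C(=Cc2ccco2)C(=O)N(c2ccc(Cl)cc2)N1c1ccc(Cl)cc1` keeps the shared core and changes one group: furan-2-yl in place of 3,4-dimethoxyphenyl on a double-bonded chain carbon bound to a double-bonded ring carbon. Here furan-2-yl replaces 3,4-dimethoxyphenyl on a double-bonded chain carbon bound to a double-bonded ring carbon.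

Among the measured compounds shown here, all the measured steps involve this same place. Two are readable and beyond the scatter: an at least 4.7-fold lower number from compound 1 to compound 2 (0.68 log units; beyond the scatter) and an at least 4.7-fold higher number from compound 2 to compound 3 (0.68 log units; beyond the scatter). The third, a step that the two limits leave unreadable from compound 1 to compound 3, cannot be sized. So changing this group can move the number, but among these compounds only compound 2 has a measured value, and compound 4 may well stay at the limit.

At best, a modest move to a lower number is expected in this assay, similar in size to the steps involving compound 2. The estimated step is an at least 1.8-fold lower number from compound 3 to compound 4 (0.26 log units; that floor lies within the scatter). The estimate for compound 4 is 70000 nM, with an expected range from 20000 nM to 128000 nM.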

Compound 4, half-maximal inhibitory concentration: 20300 nM
Compound 4: middle estimate off by 3.4-fold (0.54 log units), on the high side, within the range that was stated.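

In this assay, furan-2-yl gives a second true number at this place, so a measurable value here does not depend on the 2-hydroxy-3-methoxyphenyl group of compound 2. The smaller ring also outperforms both larger groups that ended at the limit, with an at least 6.3-fold lower number from compound 3 to compound 4 (0.79 log units; beyond the scatter) and an at least 6.3-fold lower number from compound 1 to compound 4 (0.79 log units; beyond the scatter), and both of these steps are only floors. Against the one other true number, the result is a 1.3-fold lower number from compound 2 to compound 4 (0.12 log units; within the scatter), so these two different groups cannot be told apart in this assay.

On these data alone, the step between compound 1 and compound 3 cannot be read, and the full size of the steps from those two compounds to compound 4 stays unknown: the limit of > 128000 nM in this assay, at which 2 of the 4 values shown sit. Whether a pyridine ring or a longer chain in place of furan-2-yl would give a similar value also remains open.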